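Solubility notes: from compound 3 to compound 4

The source may hold more compounds than are shown below. What is called first, only, known or untested is meant among the compounds shown, and "the series" means these compounds.

Of the compounds shown here, three sharing one core have been read in a physicochemical assay for solubility (a lower number here means a less soluble compound, a higher number a more soluble compound), and they differ on a saturated chain carbon bound to an aromatic nitrogen. Compound 1 `CNC(=O)c1cc(C(=O)NC2CC2)cn(Cc2ccc(OC)cc2)c1=O` gives >= 143 ug/mL, which is a limit of the assay and not a number. Compound 2 `CNC(=O)c1cc(C(=O)NC2CC2)cn(CC2CCCCC2)c1=O` gives >= 148 ug/mL, also a limit. Within the data shown here, compound 3 `CNC(=O)c1cc(C(=O)NC2CC2)cn(Cc2nccc3[nH]ccc23)c1=O` gives 73 ug/mL, the only actual number among the three.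

Compound 4 `CNC(=O)c1cc(C(=O)NC2CC2)cn(Cc2cccc3cn[nH]c23)c1=O` keeps the core and carries 1H-indazol-7-yl at that place: a group of 9 heavy atoms (7 carbon, 2 nitrogen; one five-membered aromatic ring with 2 hetero atoms, one six-membered aromatic ring of carbon only) in place of a group of 9 heavy atoms (7 carbon, 2 nitrogen; one five-membered aromatic ring with 1 hetero atom, one six-membered aromatic ring with 1 hetero atom), on a saturated chain carbon bound to an aromatic nitrogen. The two measured steps that bear on this change are an at least 1.9-fold lower number from compound 1 to compound 3 (0.29 log units; that floor lies within the scatter) and an at least 2.0-fold lower number from compound 2 to compound 3 (0.30 log units; that floor lies within the scatter). Each ends at compound 3, and neither floor clears the scatter. Neither step exchanges one such two-ring group for another, so the data give no direction for this change. No step beyond the scatter is expected, and the expected step is a 1.0-fold lower number from compound 3 to compound 4 (0.02 log units; within the scatter). In this assay the estimate for compound 4 is 70 ug/mL, with an expected range of 30 ug/mL to 150 ug/mL.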

Compound 4, solubility: >= 181 ug/mL
Compound 4 gave a limit, no number; the forecaster's own chance of this, stated with the estimate: 10%; at least 2.5-fold (0.41 log units) between middle value and limit.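

In this assay, among these compounds, exchanging one two-ring group for another on a saturated chain carbon bound to an aromatic nitrogen gives an at least 2.4-fold higher number from compound 3 to compound 4 (0.39 log units; beyond the scatter), the first step that clears the scatter. Among the compounds shown here, the two groups have the same atoms and the same hydrogen-bond donor and acceptor counts, so how the atoms are joined within the group is enough to move the read-out, which the earlier steps, all of which also changed the atoms, could not show. Compound 4 gives a limit of the assay and not a number, so the full size of the step stays unknown: the limit of >= 181 ug/mL in this assay, at which 1 of the 4 values shown sits.

The steps to compound 4 from compound 1 and from compound 2 cannot be read. Going by these compounds, how a carboxylic acid or a dimethylamino group would read in this assay in place of 1H-indazol-7-yl stays open.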